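Dimethylamino in place of methoxy on compound 2

A few compounds are considered here, and "the series" means these few. Any claim that something is new, unique, unknown or untested is made for them only; others in the source may bear on it.

Of the compounds shown here, three have been tested in a functional assay on the whole organism for antagonist activity, with Mus musculus as the target (on this read-out higher numbers stand for an effect only at larger amounts of compound and lower numbers for an effect already at smaller amounts), and none has yet given a number. Compound 1 (`COC(=O)N(C)CC#CCN1CCCC1`) reads > 10 mg/kg, which is a limit. Compound 2 (`COC(=O)N(C)CC#CCn1ccnc1`) reads > 100 mg/kg, which is also a limit. Compound 3 (`COC(=O)N(C)CC#CCn1cncc1C`) reads > 100 mg/kg, again a limit. Compound 2 thus stands at the limit of > 100 mg/kg in this assay, at which 2 of the 3 values shown sit, with no number of its own.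

Compound 4 (`CN(C)C(=O)N(C)CC#CCn1ccnc1`) carries dimethylamino in place of methoxy on a carbonyl carbon, so that methoxycarbonyl gives way to dimethylcarbamoyl (dimethylamino in place of methoxy on a carbonyl carbon). Neither measured step touches that carbonyl carbon, and neither offers a size to carry over. Among the measured compounds shown here, the first is a step that the two limits leave unreadable from compound 1 to compound 2, and the second is a step that the two limits leave unreadable from compound 2 to compound 3. With nothing to scale from, no step beyond the scatter is expected in this assay in either direction, and the estimated step is a step that the limit leaves unreadable from compound 2 to compound 4. For compound 4 the estimated value is 120 mg/kg, with an expected range from 30 mg/kg to 400 mg/kg, and a report of only a limit is the likeliest outcome.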

Compound 4, dose for half-maximal effect: > 100 mg/kg
Compound 4 gave a limit, no number (the forecaster's own chance of this, stated with the estimate: 75%); the middle value does not contradict the limit.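

Compound 2 and compound 4 both read only as limits in this assay, and the step between them cannot be read. The compounds shown leave open whether dimethylamino in place of methoxy on a carbonyl carbon changes the dose for half-maximal effect at all.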